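Bromo for methyl on the aryl ether of compound 2

The source may report more compounds than this note shows. Statements on the series, on what has been measured and on what is new or still open speak of the compounds shown alone.

Measured compounds:
- compound 1, `NC1=NC2(CCSCC2)N(OCCCOc2cccc(Cl)c2)C(N)=N1`: "not determined" (no result reported) in an assay on isolated protein for inhibition of Dihydrofolate reductase (Homo sapiens), read by spectrophotometry, using NADPH, with stated times of 5 s and 6 min; on this read-out lower numbers stand for stronger inhibition and higher numbers for weaker inhibition
- compound 2, `Cc1ccc(OCCCON2C(N)=NC(N)=NC23CCOCC3)cc1`: 56.8 nM
- compound 3, `NC1=NC2(CCSCC2)N(OCCCOc2ccc(Cl)cc2)C(N)=N1`: 18.3 nM

Three compounds share a core and an aryl ether arm and differ in the ring heteroatom of the core and in the substituent on the aromatic ring. In this assay, among the measured compounds shown here, compound 2 gives 56.8 nM, the higher of the two numbers known, and compound 3 gives 18.3 nM, lower by more than the usual scatter. Compound 1 gives "not determined" (no result reported), so it cannot be placed.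

Compound 4, `NC1=NC2(CCOCC2)N(OCCCOc2ccc(Br)cc2)C(N)=N1`, is not yet measured. It keeps the core of compound 2 and changes only the aromatic substituent: bromo in place of methyl on an aromatic carbon

For the measured compounds named here, no measured pair shows this single change alone, and compound 3 differs from compound 2 in the core as well as in the substituent, so its value is only a loose hint. I expect a step of modest size from compound 2 toward a lower number, a 1.9-fold lower number from compound 2 to compound 4 (0.28 log units; within the scatter), though a result within the scatter would not surprise. For compound 4 I estimate 30 nM, within 10 nM to 90 nM.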

Compound 4, half-maximal inhibitory concentration: 32.5 nM
Compound 4: the middle estimate sits 1.1-fold (0.03 log units) below what was measured; low and high end bracket the measured number.
By their numbers in this assay, from the lowest: compounds 3, 4 and 2 (each within the scatter of the next, the first and the last beyond it).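

Among the compounds shown here, with the core held fixed, this pair isolates a single change on the aromatic ring for the first time: in this assay, bromo in place of methyl, para to a large group, gives a 1.7-fold lower number from compound 2 to compound 4 (0.24 log units; within the scatter). Since that step lies within the usual scatter, methyl and bromo cannot be told apart at this position in this assay, and the exchange leaves the read-out in the same range. No separate measurement here speaks to why the two groups read alike.

The compounds shown leave open whether a very different group at this position, such as an amine or a carboxylic acid, would also fit this pattern. For the compounds shown here, also open is what exchanging the ring oxygen of the core for sulfur does alone, since no pair here changes only that atom.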